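Oral tail flick series: lysine-derived to threonine-derived amide

The source may report more compounds than this note shows. Statements on the series, on what has been measured and on what is new or still open speak of the compounds shown alone.

Measured so far:
compound 1 `NCCCC[C@H](NC(=O)CN(c1nc(Cl)nc2[nH]cnc12)C1CC1)C(=O)OCc1ccccc1` — 26.1%
compound 2 `CC[C@H](C)[C@H](NC(=O)CN(c1ncnc2c1ncn2C1CCCCO1)C1CC1)C(=O)OCc1ccccc1` — 25.6%
compound 3 `O=C(CN(c1nc(Cl)nc2[nH]cnc12)C1CC1)N[C@@H](CO)C(=O)O` — 38.7%

Read-out: a functional assay on the whole organism (Tail, strain ICR) with Mus musculus as the target, in the tail flick test, with a stated time of 30 min, at a dose of 25 umol/kg by the oral route; on this read-out higher numbers stand for a stronger effect at the one dose given and lower numbers for a weaker effect. Among the three numbers compound 1 stands second highest. Compound 2 gives a number within the scatter of it, so no order between them is claimed. Compound 3 gives a number beyond the scatter above compound 1; compound 3 differs from compound 1 in more than one place, so the gap cannot be tied to a single change.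

Compound 4 `C[C@@H](O)[C@H](NC(=O)CN(c1nc(Cl)nc2[nH]cnc12)C1CC1)C(=O)OCc1ccccc1` is not yet measured. From compound 1 it differs thus: 1-hydroxyethyl in place of 4-aminobutyl on a saturated chain carbon bound to an amide-type nitrogen and a carbonyl carbon. For the measured compounds named here, no step between measured compounds isolates this change, so the expected step from compound 1 to compound 4 in this assay is a number 3.9 percentage points higher from compound 1 to compound 4 (within the scatter), within the scatter, direction uncertain. Compound 4 is estimated at 30%, range 18% to 42%.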

Compound 4, a percentage reported as activity, at one dose (the size of the read-out at that dose, not a potency): 21.9%
For compound 4 the middle estimate is 8.1 percentage points above the measured one; low and high end bracket the measured number.
By their numbers in this assay, from the lowest: compounds 4, 2 and 1 (each within the scatter of the next); then compound 3.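

In this assay, 1-hydroxyethyl in place of 4-aminobutyl on a saturated chain carbon bound to an amide-type nitrogen and a carbonyl carbon gives a number 4.2 percentage points lower from compound 1 to compound 4 (within the scatter). For the compounds shown here, this is the first comparison that differs in one place, and at the one dose given it shows no readable difference between these two chains. No supporting data bear on this result.

From the compounds shown here alone, whether a guanidine or a phenyl group on this carbon would give a step beyond the scatter stays open. A single dose also leaves potency at this position unresolved.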